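This account rests on a few compounds, and the source may have more. Where it says the series, first, only, none or still open, it means among the compounds named here.

Measured so far in a physicochemical assay for solubility, read by LC-MS, in phosphate buffer, measured as thermodynamic solubility, with a stated time of 24 h, at pH 7.4; a lower number here means a less soluble compound, a higher number a more soluble compound:
compound 1 `Cn1cc(-c2cnc3[nH]cc(-c4ccnc(C#N)c4)c3c2)cn1` gives 2000 nM
compound 2 `Cn1cc(-c2cnc3[nH]cc(-c4ccc(O)cc4)c3c2)cn1` gives < 3000 nM

For compound 2 the figure is a limit of this assay, not a number (the limit of < 3000 nM in this assay, at which 1 of the 2 values shown sits). Compound 1 gives a number. Among the measured compounds shown here, no step between the two is measured, so their relation stays open. Compound 3 `Cn1cc(-c2cnc3[nH]cc(-c4ccncc4)c3c2)cn1` differs from compound 2 by pyridin-4-yl in place of 4-hydroxyphenyl on an aromatic carbon. For the measured compounds named here, with only a limit for compound 2 and no measured step of this kind, the step from compound 2 to compound 3 in this assay is expected to stay within the usual scatter, in no set direction, estimated as a number no lower from compound 2 to compound 3 (the limit leaves the size open). Compound 3 is expected near 3000 nM, between 800 nM and 12000 nM.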

Compound 3, solubility: 59000 nM
Estimate against measurement, compound 3: 20-fold (1.29 log units) below; the measured number lies above the stated range.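

In this assay, the number depends strongly on the group at this aromatic carbon: pyridin-4-yl in place of 4-hydroxyphenyl gives an at least 19-fold higher number from compound 2 to compound 3 (1.29 log units; beyond the scatter). A single substituent on the pyridine group also counts, as hydrogen in place of cyano on an aromatic carbon gives a 30-fold higher number from compound 1 to compound 3 (1.47 log units; beyond the scatter). The figure for compound 2 is a limit, not a number: the limit of < 3000 nM in this assay, at which 1 of the 3 values shown sits.

Which part of the change from 4-hydroxyphenyl to pyridin-4-yl carries the step stays open. So does the reading in this assay for an amine or a carboxylic acid at this position.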